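This account rests on a few compounds, and the source may have more. Where it says the series, first, only, none or still open, it means among the compounds named here.

Measured so far: compound 1 `O=C(O)c1ccccc1-c1ccc(CCc2ncc(CCC3CCCCC3)[nH]2)cc1` gave 33 nM in an in vitro functional assay on cells for agonist activity at Bombesin receptor subtype-3 (Mus musculus), read by luminescence and calcium flux; on this read-out lower numbers stand for an effect already at smaller amounts and higher numbers for an effect only at larger amounts of compound; compound 2 `CCC(C)(CC)Cc1cnc(CCc2ccc(-c3ccccc3C(=O)O)cc2)[nH]1` gave 30 nM in this assay.

Compound 2 and compound 1 are within the scatter of each other: the step of a 1.1-fold lower number from compound 1 to compound 2 (0.04 log units; within the scatter) separates nothing, so compound 2 stands level with compound 1 rather than apart from it. Compound 3 `N#Cc1ccccc1Cc1cnc(CCc2ccc(-c3ccccc3C(=O)O)cc2)[nH]1` differs from compound 2 by 2-cyanophenyl in place of 1-ethyl-1-methylpropyl on a saturated chain carbon bound to an aromatic carbon. For the measured compounds named here, the one measured step exchanges one branched alkyl group for another and says nothing about an aromatic ring carrying a nitrile; no measured pair bears on this change. The expectation therefore rests on compound 2 alone, with a wide range and a lean toward a higher number, as the change is larger in kind than the step already seen. Compound 3 is expected at 100 nM, between 20 nM and 600 nM. This estimate for compound 3 amounts to a 3.3-fold higher number from compound 2 to compound 3 (0.52 log units; beyond the scatter).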

Compound 3, half-maximal effective concentration: 642 nM
Compound 3: the middle estimate sits 6.4-fold (0.81 log units) below what was measured; measured number above the stated range.
By their numbers in this assay, from the lowest: compounds 2 and 1 (each within the scatter of the next); then compound 3.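

In this assay the place on a saturated chain carbon bound to an aromatic carbon proved far from indifferent to the group it carries: the two saturated groups had stood level, yet 2-cyanophenyl gives a 21-fold higher number from compound 2 to compound 3 (1.33 log units; beyond the scatter) and a 19-fold higher number from compound 1 to compound 3 (1.29 log units; beyond the scatter) in the second comparison. Both steps are large, so the result holds against either saturated group, and tolerance at this place does not extend from those groups to 2-cyanophenyl. Nothing available accounts for this rise in the number.

The compounds shown leave open whether the higher number goes with the aromatic ring itself or with the nitrile, as neither an unsubstituted phenyl nor a 2-methoxyphenyl group is among them. They also leave open how an amine or a hydroxyl group on a saturated chain would fare at this place.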